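Replacing Isobutylamino with Butyl(methyl)amino at the Thiocarbonyl

The compounds below may be only part of what the source reports. "The series", "measured", "known", "first", "only" and "open" are said of these compounds alone.

Compound 2 `CC(C)CNC(=S)N/N=C\c1c[nH]c2ccccc12` carries an isobutyl group on an amide-type nitrogen of the shared core. In an ADME assay on KB cells (Homo sapiens) for cytotoxicity, read by MTT assay, with a stated time of 44 h (a higher number here means a weaker inhibitor, a lower number a stronger inhibitor), compound 2 reaches only a limit of the assay and gives > 100000 nM rather than a number. Compound 1 `CC(C)NC(=S)N/N=C\c1c[nH]c2ccccc12` is the isopropyl counterpart, and in this assay compound 1 likewise gives only a limit, > 100000 nM in size. The step that the two limits leave unreadable from compound 1 to compound 2 cannot be read because both values sit at the limit of > 100000 nM in this assay, at which 2 of the 2 values shown sit, and nothing distinguishes them.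

Compound 3 `CCCCN(C)C(=S)N/N=C\c1c[nH]c2ccccc12` differs from compound 2 by butyl(methyl)amino in place of isobutylamino on a thiocarbonyl carbon. Among the measured compounds shown here, the only measured step that bears on this change is the unreadable one from compound 1 to compound 2, so it offers no size and no direction. The expected step is a number no higher from compound 2 to compound 3 (the limit leaves the size open) with no measured basis for a move beyond the scatter in either direction. Compound 3 is therefore estimated at 100000 nM in this assay, within a range from 30000 nM to 300000 nM and most likely reported again only as a limit.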

Compound 3, half-maximal inhibitory concentration: > 100000 nM
Compound 3 ended at the assay's limit; the forecaster's own chance of this, stated with the estimate: 80%; the middle value sits exactly at the limit.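

Among the compounds shown here, no step from compound 1 or compound 2 to compound 3 can be read, because all three compounds end at a limit rather than a number: the limit of > 100000 nM in this assay, at which 3 of the 3 values shown sit. The compounds shown leave open how these groups on the thiocarbonyl carbon rank in this assay.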